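The compounds below may be only part of what the source reports. "The series", "measured", "known", "first", "only" and "open" are said of these compounds alone.

Measured compounds:
compound 1, `COc1ccc(C2C(C#N)=C(N)Oc3c2c(C)nn3-c2ccccc2)cc1`, 4100 nM in a functional assay on NCI-H2122 cells (Homo sapiens) for inhibition, read by microscopy, with a stated time of 10 days; on this read-out lower numbers stand for stronger inhibition and higher numbers for weaker inhibition;
compound 2, `COc1ccc(C2C(C#N)=C(N)Oc3c2c(-c2ccccc2)nn3-c2ccccc2)cc1`, 3100 nM in this assay;
compound 3, `Cc1nn(C)c2c1C(c1ccc(OC(F)(F)F)cc1)C(C#N)=C(N)O2`, 2900 nM in this assay.

Compound 2 differs from compound 1 by phenyl in place of methyl on an aromatic carbon. That step gave a 1.3-fold lower number from compound 1 to compound 2 (0.12 log units; within the scatter). Compound 3 stands at the lowest of the three numbers, but all three lie within the scatter of one another, so no order among them is claimed. How the core of compound 3 differs from the core of compound 1 is not broken down here.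

Compound 4, `Cn1nc(-c2ccccc2)c2c1OC(N)=C(C#N)C2c1ccc(OC(F)(F)F)cc1`, remains to be measured. Among the measured compounds shown here, it differs from compound 3 by phenyl in place of methyl on an aromatic carbon, the same kind of change as the one from compound 1 to compound 2, though the surroundings differ: in the pair compound 1 to compound 2 the place lies two ring bonds from the ring atom that bears a phenyl group (6 heavy atoms), whereas for compound 3 to compound 4 it lies two ring bonds from the ring atom that bears a methyl group (1 heavy atom). Because the earlier step of a 1.3-fold lower number from compound 1 to compound 2 (0.12 log units; within the scatter) stayed within the scatter, a step of about the same small size is expected for compound 4 in this assay, namely a 1.3-fold lower number from compound 3 to compound 4 (0.10 log units; within the scatter), starting from compound 3 at 2900 nM. Compound 4 is estimated at 2300 nM, expected between 1000 nM and 5000 nM.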

Compound 4, half-maximal inhibitory concentration: 5500 nM
Beside the measured number, compound 4's estimate is 2.4-fold (0.38 log units) below it; the measured number lies above the stated range.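

In this assay, phenyl in place of methyl on an aromatic carbon gave a 1.9-fold higher number from compound 3 to compound 4 (0.28 log units; within the scatter) on the core of compound 3, a step that stays within the scatter. Set beside the earlier step on the core of compound 1, the new step does not separate the two cores: the same change on two cores in this assay, a 1.3-fold lower number (0.12 log units; within the scatter) from compound 1 to compound 2 and a 1.9-fold higher number (0.28 log units; within the scatter) from compound 3 to compound 4, 2.5-fold (0.40 log units) apart, within the scatter of two such steps. Among the compounds shown here, this shows no difference in how the change carries from one core to the other, but it does not show that the two steps are equal, and with only two pairs it fixes no direction or size for the change.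

Open, going by these compounds, is whether another group at this place, such as an amine, a carboxylic acid or a longer alkyl chain, would give a step beyond the scatter.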